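This account rests on a few compounds, and the source may have more. Where it says the series, first, only, none or still open, it means among the compounds named here.

Compound 1 `FC(F)(F)c1cc(NC[C@H]2CCCN2)c2cn[nH]c2c1` gives the higher of the two numbers measured in an assay for inhibition of Indoleamine 2,3-dioxygenase 1 (Homo sapiens), with stated times of 10 min and 60 min, tested at 100 uM (a lower number here means a weaker effect, a higher number a stronger effect of the compound at the concentration tested), at 83%. Compound 2 `O=C1NC(=O)c2c(NCc3ccccc3[N+](=O)[O-])cccc21`, built on a different core, gives 4% in this assay, a number far lower than that of compound 1 and beyond the usual scatter. Compound 3 `FC(F)(F)c1cc(NCc2cccc(Br)c2)c2cn[nH]c2c1` differs from compound 1 in one place: 3-bromophenyl in place of pyrrolidin-2-yl on a saturated chain carbon bound to a nitrogen on an aromatic ring. For the measured compounds named here, no pair of measured compounds shows this change, so its effect has not been observed. A moderate fall is expected, a number 28 percentage points lower from compound 1 to compound 3 (beyond the scatter), likely beyond the scatter. Compound 3 is therefore estimated at 55% in this assay, with a range from 15% to 90%.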

Compound 3, a percentage reported as inhibition, at one concentration (the size of the read-out at that concentration, not a potency): 51%
Beside the measured number, compound 3's estimate is 4 percentage points above it; measured number inside the range.
By their numbers in this assay, from the lowest: compound 2; then compound 3; then compound 1.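

In this assay, putting 3-bromophenyl in place of pyrrolidin-2-yl on the saturated chain carbon gives a number 32 percentage points lower from compound 1 to compound 3 (beyond the scatter), so the group at this position matters. Even so, compound 3 gives 51%, which shows that a substantial effect remains with an all-carbon aromatic ring and no hydrogen-bond donor or acceptor in the group. Nothing available explains the fall. Still open, from the compounds shown here alone, is whether the step tracks the loss of the pyrrolidine or the arrival of the bromophenyl. An unsubstituted phenyl or an open-chain amine at this position would help separate the two.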